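This account rests on a few compounds, and the source may have more. Where it says the series, first, only, none or still open, it means among the compounds named here.

Measured compounds:
Compound 1, `COC1=C(C)C(=O)/C(=C(O)/C=C/c2ccccc2OC)C(=O)C1(C)C`: 2.5 ug/mL
Compound 2, `COC1=C(C)C(=O)/C(=C(O)/C=C/c2ccc(O)cc2)C(=O)C1(C)C`: 2.9 ug/mL
Compound 3, `COC1=C(C)C(=O)/C(=C(O)/C=C/c2ccc(F)cc2)C(=O)C1(C)C`: "not determined" (no result reported)

The three compounds share one core and differ only in the aromatic group at the end of the chain. In a functional assay on 1A9 cells (Homo sapiens) for cytotoxicity (on this read-out higher numbers stand for an effect only at larger amounts of compound and lower numbers for an effect already at smaller amounts), compound 1 gives 2.5 ug/mL, and compound 2 gives 2.9 ug/mL; for compound 3 no number was reported. Among the measured compounds shown here, compound 1 therefore holds the lowest of the two numbers known, with compound 2 nearest to it: the step of a 1.2-fold higher number from compound 1 to compound 2 (0.06 log units; within the scatter) is within the scatter, so the two cannot be placed in any order.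

Compound 4, `COC1=C(C)C(=O)/C(=C(O)/C=C/c2nccs2)C(=O)C1(C)C`, is not yet measured. It differs from compound 1 in one place: 1,3-thiazol-2-yl in place of 2-methoxyphenyl on a double-bonded chain carbon bound to a double-bonded chain carbon. For the measured compounds named here, the only measured step, a 1.2-fold higher number from compound 1 to compound 2 (0.06 log units; within the scatter), swaps one substituted phenyl for another and shows no change beyond the scatter. Going by the values given here, no step in this set replaces the six-membered carbon ring by a five-membered ring with two hetero atoms, so the present change is larger than anything that was tested and its outcome is uncertain. Compound 4 is expected to stay near compound 1, with a step of a 1.4-fold higher number from compound 1 to compound 4 (0.15 log units; within the scatter) that may well fall within the scatter, and a somewhat higher number is thought slightly more likely than a lower one. The estimate for compound 4 in this assay is 3.5 ug/mL, with a range from 1.5 ug/mL to 9 ug/mL.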

Compound 4, concentration for half-maximal effect: 3.5 ug/mL
The estimate for compound 4 equals the measured number at the digits printed, and the stated range covers the measured number.
By their numbers in this assay, from the lowest: compounds 1, 2 and 4 (each within the scatter of the next).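

In this assay the aromatic group at the end of the chain was now exchanged for a different kind of ring: 1,3-thiazol-2-yl in place of 2-methoxyphenyl gives a 1.4-fold higher number from compound 1 to compound 4 (0.15 log units; within the scatter), and the same ring in place of 4-hydroxyphenyl gives a 1.2-fold higher number from compound 2 to compound 4 (0.08 log units; within the scatter). The earlier comparison had set one substituted phenyl against another, whereas these steps show that, for these compounds, on a double-bonded chain carbon bound to a double-bonded chain carbon, a five-membered aromatic ring with 2 hetero atoms and fewer heavy atoms leaves the number within the scatter of both six-membered aromatic rings of carbon only. Nothing measured here accounts for why the number holds across these three groups.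

From the compounds shown here alone, all three compounds with a number carry an aromatic ring at this place, so it remains open whether a group without one, such as a longer saturated carbon chain or a piperidine ring, would stay in the same range. Going by these compounds, it is equally open whether a carboxylic acid or a dimethylamino group on the phenyl ring would keep the number there, or move it beyond the scatter.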